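Working notes: from compound 3 to compound 4

A few compounds are considered here, and "the series" means these few. Any claim that something is new, unique, unknown or untested is made for them only; others in the source may bear on it.

In a functional assay on MDA-MB-231 cells (Homo sapiens) for antiproliferative activity, read by MTT assay, with a stated time of 72 h (on this read-out lower numbers stand for stronger inhibition and higher numbers for weaker inhibition), compound 1 (`CC1=CC[C@H]2[C@H](CC[C@]2(C)O)C(C)(C)[C@@H]1CC[C@H]1[C@]2(C)CC[C@H](OC(=O)CCC(=O)O)C(C)(C)O[C@H]2CC[C@@]1(C)O`) gives 27900 nM and compound 2 (`CC1=CC[C@H]2[C@H](CC[C@]2(C)O)C(C)(C)[C@@H]1CC[C@H]1[C@]2(C)CC[C@H](OC(=O)c3ccccc3)C(C)(C)O[C@H]2CC[C@@]1(C)O`) gives 16100 nM while compound 3 (`CC1=CC[C@H]2[C@H](CC[C@]2(C)O)C(C)(C)[C@@H]1CC[C@H]1[C@]2(C)CC[C@H](OC(=O)c3ccc(F)cc3)C(C)(C)O[C@H]2CC[C@@]1(C)O`) gives 11300 nM on the same read-out. Compound 3 stands with compound 2 inside the scatter and clear of compound 1 only, as shown by a 2.5-fold lower number from compound 1 to compound 3 (0.39 log units; beyond the scatter) in contrast with a 1.7-fold lower number from compound 1 to compound 2 (0.24 log units; within the scatter) for the other aryl member.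

The next member is compound 4 (`CC1=CC[C@H]2[C@H](CC[C@]2(C)O)C(C)(C)[C@@H]1CC[C@H]1[C@]2(C)CC[C@H](OC(=O)c3cccc(C(F)(F)F)c3)C(C)(C)O[C@H]2CC[C@@]1(C)O`), and the change is 3-(trifluoromethyl)phenyl in place of 4-fluorophenyl on a carbonyl carbon with 3-(trifluoromethyl)phenyl in place of 4-fluorophenyl on a carbonyl carbon. Among the measured compounds shown here, the nearest precedent is an exchange between two aryl groups, a 1.4-fold lower number from compound 2 to compound 3 (0.15 log units; within the scatter) and thus within the scatter. For the measured compounds named here, no measured compound yet carries a trifluoromethyl group, so this precedent is only a loose guide. The expected step is a 1.1-fold lower number from compound 3 to compound 4 (0.05 log units; within the scatter) and so no shift beyond the scatter is anticipated in this assay in either direction. Compound 4 is estimated at 10000 nM (expected range 5000 nM to 21000 nM)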

Compound 4, half-maximal inhibitory concentration: 36300 nM
For compound 4 the middle estimate is 3.6-fold (0.56 log units) below the measured one; the measured number lies above the stated range.
By their numbers in this assay, from the lowest: compounds 3, 2, 1 and 4 (each within the scatter of the next, the first and the last beyond it).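

In this assay, exchange of one aryl group for another on this carbonyl carbon now has an effect beyond the scatter: 3-(trifluoromethyl)phenyl in place of 4-fluorophenyl gives a 3.2-fold higher number from compound 3 to compound 4 (0.51 log units; beyond the scatter). Adding the trifluoromethyl group to the phenyl ring gives a 2.3-fold higher number from compound 2 to compound 4 (0.35 log units; beyond the scatter), whereas fluoro in place of hydrogen had produced no step beyond the scatter. Among the compounds shown here, with a 1.3-fold higher number from compound 1 to compound 4 (0.11 log units; within the scatter), an aryl group at this place does not by itself separate a compound from compound 1, and compound 3 remains the only member clear of it.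

No available evidence accounts for these steps. Still open, as far as these compounds go, is whether the step from compound 3 to compound 4 follows the trifluoromethyl group or its place on the ring, and what an amine or a carboxylic acid on that ring would give.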